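Cyclopentyl at the ring carbon of compound 3

The compounds below may be only part of what the source reports. "The series", "measured", "known", "first", "only" and "open" are said of these compounds alone.

Three members of the series have numbers in an assay (strain Wistar) for inhibition of Hormone-sensitive lipase (Rattus norvegicus), read by spectrophotometry; on this read-out higher numbers stand for weaker inhibition and lower numbers for stronger inhibition. Compound 1 `Cc1c(C)n(C(=O)N2CCCCC2)oc1=O` gives 13 nM, compound 2 `Cc1c(C(C)C)c(=O)on1C(=O)N1CCCCC1` gives 2 nM, and compound 3 `Cc1c(CC(C)C)c(=O)on1C(=O)N1CCCCC1` gives 5 nM. Compound 3 thus stands second highest of the three, separated from compound 2 by a 2.5-fold higher number from compound 2 to compound 3 (0.40 log units; beyond the scatter) and from compound 1 by a 2.6-fold lower number from compound 1 to compound 3 (0.41 log units; beyond the scatter). Compound 4 `Cc1c(C2CCCC2)c(=O)on1C(=O)N1CCCCC1` is not yet measured; it differs from compound 3 by cyclopentyl in place of isobutyl on an aromatic carbon.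

For the measured compounds named here, two measured steps bear on this change, both at the same aromatic carbon. Enlarging methyl to isopropyl gave a 6.5-fold lower number from compound 1 to compound 2 (0.81 log units; beyond the scatter), while going on from isopropyl to isobutyl gave a 2.5-fold higher number from compound 2 to compound 3 (0.40 log units; beyond the scatter). A group branched at the point of attachment, as cyclopentyl is, therefore sits nearer the isopropyl case than the isobutyl case on the evidence so far, though no ring has yet been tried at this position. A modest step toward lower numbers in this assay is expected, about a 1.7-fold lower number from compound 3 to compound 4 (0.22 log units; within the scatter). Compound 4 is estimated at 3 nM, with a range from 1 nM to 8 nM.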

Compound 4, half-maximal inhibitory concentration: 6 nM
Estimate against measurement, compound 4: 2.0-fold (0.30 log units) below, within the range that was stated.
By their numbers in this assay, from the lowest: compound 2; then compounds 3 and 4 (each within the scatter of the next); then compound 1.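

In this assay, a ring at this aromatic carbon, with branching at the point of attachment, does not separate from the open isobutyl chain: a 1.2-fold higher number from compound 3 to compound 4 (0.08 log units; within the scatter). Branching at the point of attachment therefore does not by itself give the isopropyl result, as a 3.0-fold higher number from compound 2 to compound 4 (0.48 log units; beyond the scatter), whereas the gain over methyl persists, with a 2.2-fold lower number from compound 1 to compound 4 (0.34 log units; beyond the scatter). No measurement in hand explains why cyclopentyl and isopropyl differ here.

Open, as far as these compounds go, is whether cyclopropyl or cyclobutyl at this aromatic carbon would track compound 2 or stay with compound 4. Also open, from the compounds shown here alone, is how a longer chain such as n-pentyl, or a chain carrying an amine or a carboxylic acid, would fare at this position.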